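Swapping dimethyl for dichloro on the amide aryl

The compounds below may be only part of what the source reports. "The series", "measured", "known", "first", "only" and "open" are said of these compounds alone.

Of the compounds shown here, three of a shared core have been measured in an assay on HEK293 cells for displacement of a labelled ligand from metabotropic glutamate receptor 5 (Rattus norvegicus); a lower number here means a stronger inhibitor, a higher number a weaker inhibitor. Compound 1 `O=C(Nc1cc(-c2ccccc2)nn1-c1ccccc1)c1ccccc1` gives 4180 nM. Compound 2 `O=C(O)c1ccc(C(=O)Nc2cc(-c3ccccc3)nn2-c2ccccc2)cc1` reaches only > 10000 nM, which is a limit of the assay and not a number (the limit of > 10000 nM in this assay, at which 1 of the 3 values shown sits). Compound 3 `Cc1ccc(C(=O)Nc2cc(-c3ccccc3)nn2-c2ccccc2)cc1C` gives 430 nM, the lowest number among the three. The step of an at least 2.3-fold higher number from compound 1 to compound 2 (0.37 log units; beyond the scatter) raised the number, the step of a 9.7-fold lower number from compound 1 to compound 3 (0.99 log units; beyond the scatter) lowered it, and the step of an at least 23-fold lower number from compound 2 to compound 3 (1.36 log units; beyond the scatter) is the largest seen here.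

Compound 4 `O=C(Nc1cc(-c2ccccc2)nn1-c1ccccc1)c1ccc(Cl)c(Cl)c1` is not yet measured. It differs from compound 3 by 3,4-dichlorophenyl in place of 3,4-dimethylphenyl on a carbonyl carbon. Within the data shown here, none of the measured steps exchanges one 3,4-disubstituted phenyl for another. The nearest guide is the step of a 9.7-fold lower number from compound 1 to compound 3 (0.99 log units; beyond the scatter), which shows that two small groups on this phenyl can move the number well beyond the scatter, while the step of an at least 2.3-fold higher number from compound 1 to compound 2 (0.37 log units; beyond the scatter) shows that a carboxy group on the same ring costs. The entering group brings no donor and no acceptor, so compound 4 is expected to stay near compound 3 rather than fall back toward compound 1. Compound 4 is estimated at 350 nM, between 90 nM and 1400 nM. The expected step of a 1.2-fold lower number from compound 3 to compound 4 (0.09 log units; within the scatter) would sit within the scatter.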

Compound 4, inhibition constant: 160 nM
Beside the measured number, compound 4's estimate is 2.2-fold (0.34 log units) above it; the range from low to high includes it.
By their numbers in this assay, from the lowest: compound 4; then compound 3; then compound 1. At a limit, above all of these: compound 2.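

The exchange on a carbonyl carbon whose other neighbour is the amide-type nitrogen is now a step of its own in this assay (a 2.7-fold lower number from compound 3 to compound 4 (0.43 log units; beyond the scatter)), so this position tells 3,4-dichlorophenyl from 3,4-dimethylphenyl even though the two groups have the same counts of heavy atoms, hydrogen-bond donors and hydrogen-bond acceptors. Starting from the plain phenyl of compound 1, the dichloro group goes further (a 26-fold lower number from compound 1 to compound 4 (1.42 log units; beyond the scatter)) than the dimethyl group did (a 9.7-fold lower number from compound 1 to compound 3 (0.99 log units; beyond the scatter)), which shows that the gain depends on which two substituents the ring carries and not only on there being two. The step from the carboxy compound (an at least 62-fold lower number from compound 2 to compound 4 (1.79 log units; beyond the scatter)) is only a bound, and compound 2 stands at a limit of the assay and not at a number: the limit of > 10000 nM in this assay, at which 1 of the 4 values shown sits.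

As far as these compounds go, what a single chlorine on this phenyl would give stays open, so the shares of the two chlorines in the gain cannot be told apart. Also open, from the compounds shown here alone, is whether bromine or trifluoromethyl in place of the chlorines would lower the number further, or raise it again.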